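A few compounds are considered here, and "the series" means these few. Any claim that something is new, unique, unknown or untested is made for them only; others in the source may bear on it.

Compound 1 `NC[C@@H]1C[C@@]1(C(=O)N1C=CCCC1)c1ccsc1` was tested in an assay on HEK293 cells for inhibition of sodium-dependent dopamine transporter (Homo sapiens); a higher number here means a weaker inhibitor, a lower number a stronger inhibitor. In this assay compound 1 gives only a limit, > 10000 nM, and no number. Two related compounds were measured alongside it. Compound 2 `CCN(CC)C(=O)[C@@]1(c2ccsc2)C[C@H]1CNC` also reaches only the limit of this assay, > 10000 nM. Going by the values given here, compound 3 `CCN(CC)C(=O)[C@@]1(c2ccccn2)C[C@H]1CN` likewise sits at the limit of this assay, > 10000 nM. the limit of > 10000 nM in this assay, at which 3 of the 3 values shown sit, summarises where the three measured values stand: none of them yields a number, so no step between measured compounds can be drawn, and compound 1 cannot be placed relative to its companions.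

Compound 4 `C=C(F)CN(C)C(=O)[C@@]1(c2ccsc2)C[C@H]1CN` has not yet been measured. It differs from compound 1 in one place a group of 6 heavy atoms (4 carbon, 1 nitrogen, 1 fluorine; no ring) in place of a group of 6 heavy atoms (5 carbon, 1 nitrogen; one six-membered non-aromatic ring with 1 hetero atom), on a carbonyl carbon whose other neighbour is a saturated ring carbon. With every measured compound at the limit, nothing here gives the size or direction of such a change. The expected step is a step that the limit leaves unreadable from compound 1 to compound 4, no movement beyond the scatter that a limit allows one to tell. Compound 4 is estimated to give 15000 nM in this assay, within 4000 nM to 60000 nM, and is most likely to return only a limit again.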

Compound 4, half-maximal inhibitory concentration: > 10000 nM
Compound 4: only a limit was reported; the forecaster's own chance of this, stated with the estimate: 75%; the middle value does not contradict the limit.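

Compound 4, like compound 1, returns only a limit, so no step can be read between compound 1 and compound 4: the limit of > 10000 nM in this assay, at which 4 of the 4 values shown sit. The compounds shown leave open whether any change on the carbonyl carbon would bring a number in this assay at all.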